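The compounds below may be only part of what the source reports. "The series", "measured", "known", "first", "only" and "open" are said of these compounds alone.

Going by the values given here, compound 3 `N#Cc1cccc(COc2ccc(-c3cc(CN4CCN(Cc5ccc(C(F)(F)F)cc5)CC4)no3)cc2)c1` carries the lowest of the three numbers measured so far in a functional assay on MCF7 cells (Homo sapiens) for antiproliferative activity, read by sulforhodamine B assay, with a stated time of 72 h (a lower number here means a stronger inhibitor, a higher number a weaker inhibitor), where compound 3 gives 800 nM. Its nearest neighbour is compound 2 `FC(F)(F)c1ccc(CN2CCN(Cc3cc(-c4ccc(OCc5cccc(Cl)c5)cc4)on3)CC2)cc1`, which in this assay gives 1400 nM; here a 1.8-fold lower number from compound 2 to compound 3 (0.24 log units; within the scatter), so these two cannot be separated. The furthest is compound 1 `Cc1cccc(COc2ccc(-c3cc(CN4CCN(Cc5ccc(C(F)(F)F)cc5)CC4)no3)cc2)c1`, which in this assay gives 4000 nM, and here a 5.0-fold lower number from compound 1 to compound 3 (0.70 log units; beyond the scatter).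

Compound 4 `COc1cccc(COc2ccc(-c3cc(CN4CCN(Cc5ccc(C(F)(F)F)cc5)CC4)no3)cc2)c1` has not yet been measured. It differs from compound 3 in a single place: methoxy in place of cyano on an aromatic carbon.

The steps measured so far all change the same group on the same ring. In this assay a 2.9-fold lower number from compound 1 to compound 2 (0.46 log units; beyond the scatter) and a 5.0-fold lower number from compound 1 to compound 3 (0.70 log units; beyond the scatter), whereas a 1.8-fold lower number from compound 2 to compound 3 (0.24 log units; within the scatter). Methyl therefore gave the highest number, and chloro and cyano gave numbers that lie within the scatter of each other. Methoxy has no counterpart among the measured compounds, so its effect is open; the measured range spans methyl at the high end and chloro and cyano at the low end. A number somewhere in the middle of that range is the expectation, which means a step of a 2.5-fold higher number from compound 3 to compound 4 (0.40 log units; beyond the scatter). Compound 4 is accordingly expected to give about 2000 nM in this assay, with a range from 800 nM to 5000 nM.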

Compound 4, half-maximal inhibitory concentration: 2000 nM
Compound 4: middle estimate and measured number agree at the digits printed, and the stated range covers the measured number.
By their numbers in this assay, from the lowest: compounds 3, 2, 4 and 1 (each within the scatter of the next, the first and the last beyond it).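

Swapping the nitrile for methoxy gives a 2.5-fold higher number from compound 3 to compound 4 (0.40 log units; beyond the scatter) in this assay, even though the two groups have the same counts of heavy atoms and hydrogen-bond acceptors, so those counts alone do not set the number at this position on the ring. Methoxy cannot be separated from chloro, with a 1.4-fold higher number from compound 2 to compound 4 (0.15 log units; within the scatter), or from methyl, with a 2.0-fold lower number from compound 1 to compound 4 (0.30 log units; within the scatter), although chloro and methyl can be separated from each other. The four groups therefore do not fall into two clean sets, and the steps overlap: methoxy sits within the scatter of two groups, apart from the nitrile, while chloro cannot be told from either the nitrile or methoxy.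

The compounds shown leave open whether a fluorine, a hydroxyl, an amine or a carboxylic acid at this position would stay within this narrow span of numbers or fall outside it, and whether the same steps would hold for these groups elsewhere on the ring. No measurement here accounts for the gap between the nitrile and methoxy compounds.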